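Removing a methyl from a phenol ether in a cytotoxicity series

This account rests on a few compounds, and the source may have more. Where it says the series, first, only, none or still open, it means among the compounds named here.

Measured so far:
- compound 1 `Cc1cc(O)cc(-c2nn(CC#N)cc2-c2ccnc(-c3ccc(Oc4ccccc4)cc3)c2)c1` — in a functional assay on LOX IMVI cells (Homo sapiens) for cytotoxicity, read by sulforhodamine B assay, with a stated time of 48 h, tested at 0.001 uM (on this read-out lower numbers stand for a stronger effect and higher numbers for a weaker effect at the one concentration tested), compound 1 gives 100%
- compound 2 `COc1cc(C)cc(-c2nn(CC#N)cc2-c2ccnc(-c3ccc(N(C)C)cc3)c2)c1` — in this assay compound 2 gives 98%

Compound 2 has the smaller of the two numbers, but the gap to compound 1 lies within the usual scatter of repeated measurements, so neither compound can be called the stronger one on these data; both read close to the level of untreated cells at the single concentration used.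

Compound 3 `Cc1cc(O)cc(-c2nn(CC#N)cc2-c2ccnc(-c3ccc(N(C)C)cc3)c2)c1` has not been measured yet. It differs from compound 2 in one place: hydrogen in place of methyl on an oxygen on an aromatic ring. Compound 1, which already carries the 3-hydroxy-5-methylphenyl group, sits at the same level as compound 2, so the change is not expected to move the read-out beyond the scatter, in either direction. The step of a number 1 percentage points higher from compound 2 to compound 3 (within the scatter) is therefore estimated to be essentially flat.

Compound 3 is expected to give about 99% in this assay, with a plausible range from 90% to 106%.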

Compound 3, a percentage reported as activity, at one concentration (the size of the read-out at that concentration, not a potency): 103%
The estimate for compound 3 lay 4 percentage points below the measured number; low and high end bracket the measured number.
By their numbers in this assay, from the lowest: compounds 2, 1 and 3 (each within the scatter of the next).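

Going from methoxy to hydroxy, that is from 3-methoxy-5-methylphenyl to 3-hydroxy-5-methylphenyl, gives in this assay a number 5 percentage points higher from compound 2 to compound 3 (within the scatter) and is the first direct test of this oxygen substituent with everything else in the molecule held the same. With the hydroxy group kept fixed, dimethylamino in place of phenoxy on the other side of the molecule gives a number 3 percentage points higher from compound 1 to compound 3 (within the scatter), so neither change separates the compounds, and all three read alike at the single very low concentration used. Nothing measured here helps to explain this flat picture, and a flat result at one concentration cannot show that the two groups are truly equivalent.

The compounds shown leave open whether the oxygen on this ring matters at all, since an amine or a fluorine in its place, or a longer chain such as ethoxy, is not among them. Also open, going by these compounds, is how methoxy and hydroxy would compare at higher concentrations, where the read-out might fall clearly away from the level of untreated cells and a real difference could appear.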